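The source may hold more compounds than are shown below. What is called first, only, known or untested is meant among the compounds shown, and "the series" means these compounds.

The study measures three compounds in a functional assay on the whole organism with Mus musculus as the target, with a stated time of 1 h, at a dose of 100 mg/kg by the intraperitoneal route (on this read-out higher numbers stand for more inhibition at the one dose given (going by the name of the read-out) and lower numbers for less inhibition), and leaves a fourth to be measured. Compound 1 `Fc1ccccc1COc1nc2ccccc2s1` gives 74.6% in this assay. Compound 3 `Fc1ccc(OCCOc2nc3ccccc3s2)cc1` gives 72.7%, and compound 2 `Clc1ccc(OCCOc2nc3ccccc3s2)cc1` gives 66.3%; all three numbers lie within the scatter of one another. The difference between the core of compound 1 and the core of compound 3 is not broken down here. Compound 3 and compound 2 differ in one place, (chloro in place of fluoro on an aromatic carbon), and the step this change made is a number 6.4 percentage points lower from compound 3 to compound 2 (within the scatter). Compound 4 `Clc1ccccc1COc1nc2ccccc2s1` has not yet been measured; it differs from compound 1 by chloro in place of fluoro on an aromatic carbon. Among the measured compounds shown here, this is the same kind of change as the one between compound 3 and compound 2, but not the same change: in compound 4 the chloro sits ortho to a large group, whereas in compound 2 it sits para to a large group. For the measured compounds named here, the step from compound 1 to compound 4 is expected to be a number 5.6 percentage points lower from compound 1 to compound 4 (within the scatter), resting on the single earlier step of this kind, which stayed within the scatter. Compound 4 is accordingly expected to give 69% in this assay, estimated to fall between 56% and 81%.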

Compound 4, a percentage reported as inhibition, in the whole organism at one dose (the size of the read-out at that dose, not a potency): 14.6%
Compound 4: the middle estimate sits 54.4 percentage points above what was measured; measured number below the stated range.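

On the core of compound 1, chloro in place of fluoro on an aromatic carbon gave a number 60 percentage points lower from compound 1 to compound 4 (beyond the scatter) in this assay, so in this series a step of this kind cannot be carried from one core to another with its size intact. The two readings of the same change disagree: the same change on two cores in this assay, a number 6.4 percentage points lower (within the scatter) from compound 3 to compound 2 and a number 60 percentage points lower (beyond the scatter) from compound 1 to compound 4, 53.6 percentage points apart, beyond the scatter of two such steps This does not show what sets them apart, since the two pairs differ both in their core and in where the halogen sits, with the chloro in compound 4 ortho to a large group, and two steps cannot separate these differences or support a general rule.

The compounds shown leave open whether chloro ortho to a large group on the core of compound 3 would bring a drop of similar size. They also leave open how bromo, methyl or methoxy in that place on the core of compound 1 would read in this assay.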